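Shortening the thioamide chain on two pyridazinone cores

The compounds below may be only part of what the source reports. "The series", "measured", "known", "first", "only" and "open" are said of these compounds alone.

Compound 3 `N=C(S)CCCCCn1nc(-c2ccccc2)ccc1=O` gives 91.4% in a functional assay on the whole organism (stomach) for inhibition, with Rattus norvegicus as the target, at a dose of 100 mg/kg by the intraduodenal route; a higher number here means more inhibition at the dose given (going by the name of the read-out), a lower number less inhibition. Compound 1 `N=C(S)CCCn1nc(-c2ccccc2)ccc1=O` gives 75.6% in this assay. The step between them is a number 15.8 percentage points lower from compound 3 to compound 1 (beyond the scatter), and the change that makes it is a group of 3 heavy atoms (1 carbon, 1 nitrogen, 1 sulfur; no ring) in place of a group of 5 heavy atoms (3 carbon, 1 nitrogen, 1 sulfur; no ring), on a saturated chain carbon, three bonds along the chain from an aromatic nitrogen. Compound 2 `Cc1ccc(=O)n(CCCCCCC(=N)S)n1` gives 29.5% in this assay, the lowest of the three measured numbers; how its core differs from the core of compound 3 is not broken down here. Compound 4 `Cc1ccc(=O)n(CCCCC(=N)S)n1` is not yet measured; it differs from compound 2 by a group of 3 heavy atoms (1 carbon, 1 nitrogen, 1 sulfur; no ring) in place of a group of 5 heavy atoms (3 carbon, 1 nitrogen, 1 sulfur; no ring), on a saturated chain carbon, four bonds along the chain from an aromatic nitrogen. This is the same kind of change as that from compound 3 to compound 1, not the same change, since the place in compound 2 is four bonds along the chain from an aromatic nitrogen rather than three, and the core is another. Given that shortening the chain cost a number 15.8 percentage points lower from compound 3 to compound 1 (beyond the scatter), a step of similar size is expected from compound 2 to compound 4, estimated at a number 14.5 percentage points lower from compound 2 to compound 4 (beyond the scatter), though starting from a far lower number. Compound 4 is thus estimated at 15% in this assay, expected to fall between 0% and 35%.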

Compound 4, a percentage reported as inhibition, in the whole organism at one dose (the size of the read-out at that dose, not a potency): 29.5%
Beside the measured number, compound 4's estimate is 14.5 percentage points below it; low and high end bracket the measured number.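

Shortening the chain on the core of compound 2 gives no change at the digits printed from compound 2 to compound 4 (within the scatter) in this assay, so the drop seen on the other core does not carry over to this one. Set side by side, the two steps clearly differ: the same change on two cores in this assay, a number 15.8 percentage points lower (beyond the scatter) from compound 3 to compound 1 and no change at the digits printed (within the scatter) from compound 2 to compound 4, 15.8 percentage points apart, beyond the scatter of two such steps This shows that the same kind of shortening need not have the same effect from one core to another in this series, but it does not show why, since the two pairs differ in their core and also in the place of the change, three bonds along the chain from an aromatic nitrogen in one and four bonds in the other.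

On these data alone, with one pair on each core, it remains open how a still shorter or a longer chain would behave on either core. As far as these compounds go, it is also open whether a carboxylic acid or an amine in place of the thioamide would keep the inhibition seen in this assay.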